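The source may report more compounds than this note shows. Statements on the series, on what has been measured and on what is new or still open speak of the compounds shown alone.

Three compounds were tested in a toxicity assay on MDCK cells (Canis lupus familiaris) for cytotoxicity, read by CCK-8 assay, with a stated time of 48 h (on this read-out lower numbers stand for higher toxicity in this test and higher numbers for lower toxicity in this test), and gave these values:

- Compound 1 `CC(C)(C)c1ccc(C(=O)NNc2c(Br)cccc2Br)cc1` gives > 100000 nM (a limit of the assay)
- Compound 2 `O=C(NNc1c(Br)cccc1Br)c1ccccc1` gives > 100000 nM (a limit of the assay)
- Compound 3 `CCN(CC)c1ccc(C(=O)NNc2c(Br)cccc2Br)cc1` gives 34000 nM (a true number)

Within the data shown here, compound 3 holds the only true number of the set, at 34000 nM on this read-out. Compound 1 and compound 2 stand at the limit of > 100000 nM in this assay, at which 2 of the 3 values shown sit, and give no number.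

The next compound, compound 4 `O=C(NNc1c(Br)cccc1Br)c1ccc(O)cc1` carries hydroxy in place of diethylamino on an aromatic carbon, para to a large group (hydroxy in place of diethylamino on an aromatic carbon).

Among the measured compounds shown here, two measured steps bear on this change. Diethylamino arrived with a lower number each time (an at least 2.9-fold lower number from compound 2 to compound 3 (0.46 log units; beyond the scatter)) and (an at least 2.9-fold lower number from compound 1 to compound 3 (0.46 log units; beyond the scatter)). Both steps are at least modest, and each has a limit at one end. No size can be read from the third step (a step that the two limits leave unreadable from compound 1 to compound 2). For the measured compounds named here, no measured compound carries hydroxy.

With diethylamino gone, a higher number is expected for compound 4, undoing something like the step (an at least 2.9-fold lower number from compound 2 to compound 3 (0.46 log units; beyond the scatter)) in the opposite direction. The expected change is modest or larger (a 2.4-fold higher number from compound 3 to compound 4 (0.37 log units; beyond the scatter)). For compound 4 the estimated value is 80000 nM with an expected range from 35000 nM to 200000 nM and a fair chance that the assay reports only a limit.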

Compound 4, half-maximal cytotoxic concentration: > 100000 nM
Compound 4: a limit, no number; the forecaster's own chance of this, stated with the estimate: 55%; middle value at least 1.2-fold (0.09 log units) away from the limit.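

In this assay, hydroxy in place of diethylamino on this aromatic carbon gives an at least 2.9-fold higher number from compound 3 to compound 4 (0.46 log units; beyond the scatter). This adds a third group to hydrogen and tert-butyl that leaves the compound at the limit, so among the four compounds shown, only compound 3, with diethylamino, gives a true number. Among these compounds, the lower number therefore goes with diethylamino alone in this small set, and no compound goes against that pattern, though the comparison rests on a single true number. The steps from compound 1 and from compound 2 to compound 4 cannot be read, and the value of compound 4 is a limit, not a number: the limit of > 100000 nM in this assay, at which 3 of the 4 values shown sit.

As far as these compounds go, it remains open whether the lower number needs the ethyl chains or only the nitrogen, a question that a plain amine or dimethylamino at this place would address. From the compounds shown here alone, how hydrogen, tert-butyl and hydroxy rank against one another also stays open, as does whether a carboxylic acid here would join them at the limit or give a true number.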